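A few compounds are considered here, and "the series" means these few. Any claim that something is new, unique, unknown or untested is made for them only; others in the source may bear on it.

Working notes on the series: two compounds have been read so far in a functional assay on MCF7 cells (Homo sapiens) for antiproliferative activity, read by CCK-8 assay, with a stated time of 72 h; a higher number here means a weaker inhibitor of growth, a lower number a stronger inhibitor of growth. Compound 1 (`CCC1C(=O)N(C)c2cnc(-n3ccc4cc(C(=O)NC)ccc43)nc2N1c1ccn(C)n1`) gives 35400 nM and compound 2 (`CC[C@@H]1C(=O)N(C)c2cnc(-n3ccc4ccccc43)nc2N1C1CCCC1`) gives 17200 nM. Compound 1 therefore holds the higher of the two numbers, marking it the weaker growth inhibitor, and the gap lies just beyond the scatter. Within the data shown here, no measured pair differs in one place only, so no measured step is available as a guide.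

Compound 3 (`CCC1C(=O)N(C)c2cnc(-n3ccc4cc(C(=O)NC5CCCC5)ccc43)nc2N1c1ccn(C)n1`), not yet measured, keeps the core of compound 1 and carries cyclopentyl in place of methyl on an amide-type nitrogen. In this assay only a small shift towards a lower number is expected, and a result within the scatter would be unsurprising. This cautious expectation rests on the weak starting value of compound 1 at 35400 nM and on the absence of any measured step. The estimated change is a 1.4-fold lower number from compound 1 to compound 3 (0.15 log units; within the scatter). The expected value for compound 3 is 25000 nM, with an estimated range of 9000 nM to 60000 nM.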

Compound 3, concentration for 50% growth inhibition: "not active" (no number reported)
No number was reported for compound 3; the estimate stays without a comparison.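

In this assay, among these compounds, compound 3 is reported as not active, without a number, so no step from compound 1 to compound 3 can be read. The compounds shown leave open how far cyclopentyl in place of methyl on an amide-type nitrogen shifts growth inhibition in numerical terms. No supporting data bear on this result.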